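The source may report more compounds than this note shows. Statements on the series, on what has been measured and on what is new or still open speak of the compounds shown alone.

Measured in a functional assay on the whole organism for antagonist activity, with Mus musculus as the target; on this read-out lower numbers stand for an effect already at smaller amounts and higher numbers for an effect only at larger amounts of compound:
- compound 1 `CC(=O)N(C)CC#CCn1ccnc1`: > 100 mg/kg
- compound 2 `COC(=O)N(C)CC#CCn1ccnc1`: > 100 mg/kg
- compound 3 `CN(C)C(=O)N(C)CC#CCN1CCCC1`: > 10 mg/kg

All three values are limits of the assay, not numbers. Compound 3 stands only at a limit, (the limit of > 10 mg/kg in this assay, at which 1 of the 3 values shown sits). Compound 1 and compound 2 stand at a different limit, (the limit of > 100 mg/kg in this assay, at which 2 of the 3 values shown sit).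

The next compound is compound 4 `CN(C)C(=O)N(C)CC#CCn1ccnc1`. Its difference from compound 3 is this: 1H-imidazol-1-yl in place of pyrrolidin-1-yl on a saturated chain carbon bound to a triple-bonded carbon. In short, it has 1H-imidazol-1-yl in place of pyrrolidin-1-yl on a saturated chain carbon bound to a triple-bonded carbon.

For the measured compounds named here, no measured step covers this exchange. Going by the values given here, the only step available, a step that the two limits leave unreadable from compound 1 to compound 2, has methoxy in place of methyl on a carbonyl carbon, and it offers no size to carry over. The better guide is that compound 1 and compound 2 both carry the entering 1H-imidazol-1-yl group, and neither gave a number at the doses reported.

Compound 4 is therefore expected to need large doses as well. The expected step in this assay is a step that the limit leaves unreadable from compound 3 to compound 4, toward larger doses, although this estimate is loose with only a limit at its starting point. The estimated value for compound 4 is 100 mg/kg, with an expected range of 30 mg/kg to 300 mg/kg, and the assay may well report only a limit.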

Compound 4, dose for half-maximal effect: > 100 mg/kg
Compound 4 was reported as a limit; the forecaster's own chance of this, stated with the estimate: 80%; the middle value sits exactly at the limit.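

In this assay compound 4 gives > 100 mg/kg, which is a limit of the assay and not a number. The steps linking compound 4 to compound 1, compound 2 and compound 3 cannot be read: all four values are limits. The compounds shown leave open what dose any of them would need for a half-maximal effect, and whether exchanging pyrrolidin-1-yl for 1H-imidazol-1-yl changes that dose at all.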